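The source may report more compounds than this note shows. Statements on the series, on what has been measured and on what is new or still open speak of the compounds shown alone.

Going by the values given here, compound 3 `Cc1ccc(-n2cc(NC(=O)c3cccc(NS(=O)(=O)c4ccc(Cl)cc4)c3)cn2)cc1` gives 110000 nM in an ADME assay on HEK-293T cells (Homo sapiens) for cytotoxicity, read by MTT assay, with a stated time of 48 h (a higher number here means that more compound is tolerated, a lower number that less compound is tolerated), the second highest of the three numbers so far: nearest stands compound 2 `O=C(Nc1cnn(-c2ccccc2)c1)c1cccc(NS(=O)(=O)c2ccc(Cl)cc2)c1` with 120000 nM, furthest compound 1 `Cc1ccc(-n2cc(NC(=O)c3cccc(NS(=O)(=O)c4ccccc4)c3)cn2)cc1` with 93800 nM. Both steps leading to it, a 1.2-fold higher number from compound 1 to compound 3 (0.07 log units; within the scatter) and a 1.1-fold lower number from compound 2 to compound 3 (0.04 log units; within the scatter), stayed within the scatter. Compound 4 `COc1ccc(-n2cc(NC(=O)c3cccc(NS(=O)(=O)c4ccc(Cl)cc4)c3)cn2)cc1` differs from compound 3 by methoxy in place of methyl on an aromatic carbon. Among the compounds with values here, no measured step exchanges the methyl itself; the one step that touched this ring, a 1.1-fold lower number from compound 2 to compound 3 (0.04 log units; within the scatter), was within the scatter, as was the other change, a 1.2-fold higher number from compound 1 to compound 3 (0.07 log units; within the scatter). Compound 4 is therefore expected to show no step beyond the scatter, no change at the digits printed from compound 3 to compound 4 (within the scatter). The estimate for compound 4 in this assay is 110000 nM, expected to fall between 55000 nM and 220000 nM.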

Compound 4, half-maximal cytotoxic concentration: 89800 nM
Compound 4: middle estimate off by 1.2-fold (0.09 log units), on the high side; the measured number falls inside the stated range.
By their numbers in this assay, from the lowest: compounds 4, 1, 3 and 2 (each within the scatter of the next).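

In this assay, going by these compounds alone, the change from 4-methylphenyl to 4-methoxyphenyl gives a 1.2-fold lower number from compound 3 to compound 4 (0.09 log units; within the scatter) and is the first measured step that exchanges the methyl itself; it stays within the scatter even though a hydrogen-bond acceptor enters. Methoxy in place of hydrogen at the same place gives a 1.3-fold lower number from compound 2 to compound 4 (0.13 log units; within the scatter) and is also within the scatter, so hydrogen and methoxy are not told apart here, nor are methyl and methoxy. Nothing available accounts for this result. As far as these compounds go, whether an amine or a carboxylic acid at this place would give a step beyond the scatter remains open.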